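Phenyl in place of the dimethylpyridyl group: compound 4

The compounds below may be only part of what the source reports. "The series", "measured", "known", "first", "only" and "open" are said of these compounds alone.

Three compounds of the series carry a number in a functional assay on BJAB cells (Homo sapiens) for antiproliferative activity, with a stated time of 4 days; on this read-out higher numbers stand for an effect only at larger amounts of compound and lower numbers for an effect already at smaller amounts. Compound 1 `Cc1ccc(-c2c(C)nn(-c3nc(-c4ccc(Cl)c(Cl)c4)c(SC(C)C)s3)c2C(=O)O)cc1` gives 3800 nM, compound 2 `Cc1nn(-c2nc(-c3ccc(Cl)c(Cl)c3)c(SC(C)C)s2)c(C(=O)O)c1-c1ccc(Cl)cc1` gives 2500 nM, and compound 3 `Cc1cc(-c2c(C)nn(-c3nc(-c4ccc(Cl)c(Cl)c4)c(SC(C)C)s3)c2C(=O)O)cc(C)n1` gives 580 nM. Compound 3 stands lowest of the three: the steps of a 6.6-fold lower number from compound 1 to compound 3 (0.82 log units; beyond the scatter) and a 4.3-fold lower number from compound 2 to compound 3 (0.63 log units; beyond the scatter) both reach beyond the scatter, so compound 3 is the most active of the measured set. Between compound 1 and compound 2 the step of a 1.5-fold lower number from compound 1 to compound 2 (0.18 log units; within the scatter) stays within the scatter.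

Compound 4 `Cc1nn(-c2nc(-c3ccc(Cl)c(Cl)c3)c(SC(C)C)s2)c(C(=O)O)c1-c1ccccc1` differs from compound 3 in one place: phenyl in place of 2,6-dimethylpyridin-4-yl on an aromatic carbon. The two measured steps that bear on this change are a 6.6-fold lower number from compound 1 to compound 3 (0.82 log units; beyond the scatter) and a 4.3-fold lower number from compound 2 to compound 3 (0.63 log units; beyond the scatter), both of which run toward the 2,6-dimethylpyridin-4-yl group and both of which were modest. Compound 4 moves the other way, toward a six-membered ring of carbon only, and the step of a 1.5-fold lower number from compound 1 to compound 2 (0.18 log units; within the scatter) shows that a change of substituent on such a ring left the number about where it was. The expectation for compound 4 in this assay is therefore a higher number than for compound 3, by a step of a 5.2-fold higher number from compound 3 to compound 4 (0.71 log units; beyond the scatter), placing it near compound 1 and compound 2. The estimate for compound 4 is 3000 nM, with a range from 1200 nM to 8000 nM.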

Compound 4, half-maximal effective concentration: 3000 nM
For compound 4 middle estimate and measured number coincide at the digits printed, and the stated range covers the measured number.
By their numbers in this assay, from the lowest: compound 3; then compounds 2, 4 and 1 (each within the scatter of the next).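

In this assay, among these compounds, the phenyl of compound 4 gives this position an unsubstituted reference that the earlier compounds lacked. Neither the methyl (a 1.3-fold lower number from compound 1 to compound 4 (0.10 log units; within the scatter)) nor the chloro (a 1.2-fold higher number from compound 2 to compound 4 (0.08 log units; within the scatter)) can be told apart from hydrogen on this ring, so among these three compounds a change on the carbon-only ring has no readable effect on the number. The direct exchange (a 5.2-fold higher number from compound 3 to compound 4 (0.71 log units; beyond the scatter)) confirms that, of the four groups at this place, only 2,6-dimethylpyridin-4-yl stands apart, and nothing at hand gives a reason for that separation.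

The leaving group differs from phenyl in both its ring nitrogen and its methyl groups, and these compounds do not separate the two contributions; a plain pyridin-4-yl group and a dimethylphenyl group would each isolate one of them. Also open, going by these compounds, is whether the same separation holds when the neighbouring carboxy group is replaced by a primary amide or a methyl ester.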